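Combining the chlorobenzyl and fluorophenyl variants

The compounds below may be only part of what the source reports. "The series", "measured", "known", "first", "only" and "open" are said of these compounds alone.

Two compounds of the series have numbers. Compound 1 `O=C(NOCc1ccccc1Cl)c1cn(-c2ccccc2)nc1-c1ccccc1` carries the 2-chlorobenzyl group and an unsubstituted phenyl on the core; in a functional assay on A549 cells (Homo sapiens) for antiproliferative activity, read by MTT assay, with a stated time of 48 h, in the presence of a further agent that is not named here (a higher number here means a weaker inhibitor of growth, a lower number a stronger inhibitor of growth), compound 1 gives 10300 nM. Compound 2 `O=C(NOCc1ccccc1)c1cn(-c2ccccc2)nc1-c1ccc(F)cc1` carries the plain benzyl and the fluorophenyl; in this assay compound 2 gives 10400 nM. Compound 2 holds the higher of the two numbers, but its gap to compound 1 lies within the scatter, so the two cannot be told apart.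

Compound 3 `O=C(NOCc1ccccc1Cl)c1cn(-c2ccccc2)nc1-c1ccc(F)cc1` keeps the fluorophenyl of compound 2 and brings in the change (chloro in place of hydrogen on an aromatic carbon). Going by the values given here, no step between measured compounds isolates this change. Because compound 1 with the 2-chlorobenzyl group already gives 10300 nM in this assay, no step beyond the scatter is expected here. The expected step is a 1.0-fold lower number from compound 2 to compound 3 (0.02 log units; within the scatter). Compound 3 is estimated at 10000 nM, with a range from 4000 nM to 25000 nM.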

Compound 3, concentration for 50% growth inhibition: 8330 nM
The estimate for compound 3 lay 1.2-fold (0.08 log units) above the measured number; low and high end bracket the measured number.
By their numbers in this assay, from the lowest: compounds 3, 1 and 2 (each within the scatter of the next).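

Going by these compounds alone, with the fluorophenyl held fixed, benzyl to 2-chlorobenzyl gives in this assay a 1.2-fold lower number from compound 2 to compound 3 (0.10 log units; within the scatter), the first direct reading of this chloro change on an aromatic carbon. With the 2-chlorobenzyl held fixed, going from the unsubstituted phenyl to the fluorophenyl gives a 1.2-fold lower number from compound 1 to compound 3 (0.09 log units; within the scatter), so neither single change separates its pair, and putting the two together in compound 3 gives no step beyond the scatter. No supporting data bear on these small steps.

Both changes shown are single halogens, so it remains open whether this benzyl position can move the number beyond the scatter at all. An amine or a carboxylic acid in place of the chloro would test that, as would a longer chain in place of the benzyl.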